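This account rests on a few compounds, and the source may have more. Where it says the series, first, only, none or still open, it means among the compounds named here.

Compound 1 `COC(=O)CC/N=C(\S)[C@]1(c2cccnc2)CCCC[S+]1[O-]`: > 30000 nM
Compound 2 `N/N=C(\S)[C@]1(c2cccnc2)CCCC[S+]1[O-]`: > 30000 nM

Both results come from a functional assay (aorta) for inhibition, with Rattus norvegicus as the target; a lower number here means a stronger inhibitor, a higher number a weaker inhibitor. Compound 2 stands at > 30000 nM, which is a limit of the assay and not a number. Compound 1 gives > 30000 nM, which is also a limit. Among the compounds with values here, the only measured step, a step that the two limits leave unreadable from compound 1 to compound 2, therefore has no readable size.

Compound 3 `O=C(O)CC/N=C(\S)[C@]1(c2cccnc2)CCCC[S+]1[O-]` differs from compound 2 by this change: 2-carboxyethyl in place of amino on a double-bonded nitrogen. In words, 2-carboxyethyl stands in place of amino on a double-bonded nitrogen. Within the data shown here, the only guide is the limit of > 30000 nM in this assay, at which 2 of the 2 values shown sit, so no clear step in either direction is expected in this assay, and another limit is the likeliest report. The expected change is a number no higher from compound 2 to compound 3 (the limit leaves the size open). For compound 3 the estimate is 30000 nM, with an expected range of 10000 nM to 100000 nM.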

Compound 3, concentration for 90% inhibition: > 30000 nM
Compound 3: no number, only a limit; the forecaster's own chance of this, stated with the estimate: 85%; the middle value sits exactly at the limit.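

Within the data shown here, no step among compound 1, compound 2 and compound 3 can be read in this assay, because each result is a limit and not a number: the limit of > 30000 nM in this assay, at which 3 of the 3 values shown sit.

The compounds shown leave open how strong each one really is, and whether changing the group on the double-bonded nitrogen alters the result at all.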